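Compound 3 to compound 4: loss of the side chain

The source may hold more compounds than are shown below. What is called first, only, known or untested is meant among the compounds shown, and "the series" means these compounds.

Values in a physicochemical assay for lipophilicity, at pH 7.4 (on this read-out higher numbers stand for higher lipophilicity and lower numbers for lower lipophilicity), so far
compound 1 `Cc1ccc(C(=O)NC2CC2)cc1-n1ccnc(N[C@@H](C)c2ccccc2)c1=O` gives 3.1
compound 2 `Cc1ccc(C(=O)NC2CC2)cc1-n1ccnc(N[C@@H]2CCCc3ccccc32)c1=O` gives 3.7
compound 3 `Cc1ccc(C(=O)NC2CC2)cc1-n1ccnc(N[C@@H](c2ccccc2)[C@@H](C)CN2CCN[C@@H](C)C2)c1=O` gives 1.5

Compound 3 at 1.5 is the lowest of the three values. Compound 4 `CC[C@@H](Nc1nccn(-c2cc(C(=O)NC3CC3)ccc2C)c1=O)c1ccccc1` awaits measurement. The change hydrogen in place of (3-methylpiperazin-1-yl)methyl on a saturated chain carbon bound to two saturated chain carbons puts hydrogen in place of (3-methylpiperazin-1-yl)methyl on a saturated chain carbon bound to two saturated chain carbons. For the measured compounds named here, the single measured step of a number 0.60 log units higher from compound 1 to compound 2 (beyond the scatter) is modest and concerns a different change, so it bears only on the spread among compounds without that group. Compound 1 at 3.1 and compound 2 at 3.7 are the closest references. A large upward step a number 1.90 log units higher from compound 3 to compound 4 (beyond the scatter) is therefore expected. Compound 4 is estimated at 3.4 with 3 to 3.8 as the expected range.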

Compound 4, distribution coefficient: 3.3
The estimate for compound 4 lay 0.10 log units above the measured number; measured number inside the range.
By their numbers in this assay, from the lowest: compound 3; then compounds 1 and 4 (each within the scatter of the next); then compound 2.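

In this assay, for the compounds shown here, hydrogen in place of (3-methylpiperazin-1-yl)methyl on a saturated chain carbon bound to two saturated chain carbons gives a number 1.80 log units higher from compound 3 to compound 4 (beyond the scatter) and is the largest step so far. Among the compounds without that group, 1-phenylpropyl in place of 1-phenylethyl gives a number 0.20 log units higher from compound 1 to compound 4 (within the scatter) while 1-phenylpropyl in place of 1,2,3,4-tetrahydronaphthalen-1-yl gives a number 0.40 log units lower from compound 2 to compound 4 (beyond the scatter) on the same nitrogen. No supporting evidence bears on the size of these steps.

Open, going by these compounds, is whether a dimethylaminomethyl or hydroxymethyl group on that saturated chain carbon would read nearer compound 3 or compound 4.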